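Swapping iodo for methyl on the shared core

The compounds below may be only part of what the source reports. "The series", "measured", "known", "first", "only" and "open" are said of these compounds alone.

Going by the values given here, in an ADME assay on microsomes from liver (Homo sapiens) for metabolic stability (on this read-out higher numbers stand for a longer-lived compound and lower numbers for a shorter-lived compound), three compounds have numbers so far. Compound 1 (`CC#C[C@@H](Cc1nnn[nH]1)c1ccc(OCc2ccc3sc(F)c(-c4ccccc4C)c3c2)cc1`) gives 0.0667 h in this measurement, compound 3 (`CC#C[C@@H](Cc1nnn[nH]1)c1ccc(OCc2ccc3sc(I)c(-c4ccccc4C)c3c2)cc1`) gives 0.167 h and compound 2 (`CC#C[C@@H](Cc1nnn[nH]1)c1ccc(OCc2ccc3sc(C)c(-c4ccc(OCCOC)cc4C)c3c2)cc1`) gives 1.48 h as the highest number of the three. Compound 3 therefore sits in the middle, a little above compound 1 and far below compound 2.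

The next structure is compound 4 (`CC#C[C@@H](Cc1nnn[nH]1)c1ccc(OCc2ccc3sc(C)c(-c4ccccc4C)c3c2)cc1`). It differs from compound 3 by methyl in place of iodo on an aromatic carbon and in nothing else.

Among the compounds with values here, only one measured swap touches this same carbon. Putting iodo in place of fluoro gave a 2.5-fold higher number from compound 1 to compound 3 (0.40 log units; beyond the scatter) and so was modest, though beyond the scatter. Compound 2 already holds the methyl that enters here. Compound 4 differs from compound 2 in another part of the structure as well, so the 1.48 h of compound 2 is only a weak hint upward.

A small rise at most is therefore expected. In this assay the estimated move is a 1.5-fold higher number from compound 3 to compound 4 (0.18 log units; within the scatter) and would stay within the scatter. Compound 4 is estimated at 0.25 h with an expected range from 0.09 h to 0.7 h in this measurement.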

Compound 4, half-life: 0.0667 h
Estimate against measurement, compound 4: 3.7-fold (0.57 log units) above; measured number below the stated range.
By their numbers in this assay, from the lowest: compounds 1 and 4 (each within the scatter of the next); then compound 3; then compound 2.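

In this assay, methyl brings no gain at this carbon next to the ring sulfur: putting it in place of iodo gives a 2.5-fold lower number from compound 3 to compound 4 (0.40 log units; beyond the scatter), and putting it in place of fluoro gives no change at the digits printed from compound 1 to compound 4 (within the scatter). Among the three groups seen at this carbon, iodo therefore stands apart, while fluoro and methyl cannot be told apart. The high number of compound 2 does not come with its methyl, which compound 4 shares, but goes with the other difference between them: hydrogen in place of 2-methoxyethoxy gives a 22-fold lower number from compound 2 to compound 4 (1.35 log units; beyond the scatter), a far larger step than either step seen at the carbon next to the ring sulfur.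

Nothing measured here explains why any of these numbers moves. On these data alone, it stays open whether bromo or an amine on this carbon would give a number nearer to that of iodo or to that of methyl, and whether 2-methoxyethoxy would give a step of similar size with iodo or fluoro on this carbon instead of methyl.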